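This account rests on a few compounds, and the source may have more. Where it says the series, first, only, none or still open, it means among the compounds named here.

Measured so far:
compound 1 `Oc1ccccc1CNc1ccc(F)cc1`: in a functional assay on Jurkat cells (Homo sapiens) for activation, with a stated time of 24 h (on this read-out lower numbers stand for an effect already at smaller amounts and higher numbers for an effect only at larger amounts of compound), compound 1 gives "not active" (no number reported), with no number reported.
compound 2 `Oc1ccccc1CNc1ccc(-c2ccc(F)cc2)cc1`: in this assay compound 2 gives 3860 nM.
compound 3 `Cc1ccc(-c2ccc(NCc3ccccc3O)cc2)cc1`: in this assay compound 3 gives 3790 nM.

Compound 3 carries a 4-methylphenyl group where compound 2 carries a 4-fluorophenyl group. The step of a 1.0-fold lower number from compound 2 to compound 3 (0.01 log units; within the scatter) shows that this swap made no difference beyond the scatter, so compound 3 and compound 2 stand side by side on the numbers at hand. Compound 1 lacks this outer ring altogether and gave no number at all.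

Compound 4 `Oc1ccccc1CNc1ccc(-c2ccccc2F)cc1` is the next step: 2-fluorophenyl in place of 4-methylphenyl on an aromatic carbon. Among the compounds with values here, the outer ring is kept, but the methyl is gone and the fluorine sits where the names 2-fluorophenyl and 4-fluorophenyl say, a shift around that ring which no measured pair has tested.

Within the data shown here, only one measured step bears on this change: a 1.0-fold lower number from compound 2 to compound 3 (0.01 log units; within the scatter), which exchanged methyl for fluoro on the same ring and stayed within the scatter. Among the measured compounds shown here, compound 1 shows only that removing the ring gives no number. The expectation in this assay is therefore no step beyond the scatter, with a wider range to allow for the untested shift. Compound 4 is expected to give 4000 nM, with a range from 1500 nM to 12000 nM. The estimated step of a 1.1-fold higher number from compound 3 to compound 4 (0.02 log units; within the scatter) is meant to stay within the scatter.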

Compound 4, half-maximal effective concentration: 2150 nM
Beside the measured number, compound 4's estimate is 1.9-fold (0.27 log units) above it, and the stated range covers the measured number.
By their numbers in this assay, from the lowest: compounds 4, 3 and 2 (each within the scatter of the next).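

In this assay, within the data shown here, moving the fluorine around the outer ring, from 4-fluorophenyl to 2-fluorophenyl, gave a 1.8-fold lower number from compound 2 to compound 4 (0.25 log units; within the scatter), which is the first measured test of where a substituent sits on this ring. Exchanging 4-methylphenyl for 2-fluorophenyl gave a 1.8-fold lower number from compound 3 to compound 4 (0.25 log units; within the scatter), so this second swap changes both the kind of substituent and its place on the ring and still stays inside the usual scatter. Across the three compounds that carry the outer ring, neither the identity of these small substituents nor these two places separates the numbers, and no measurement shown offers an explanation for this.

The compounds shown do not reveal whether an outer ring carrying a larger or very different group, such as a methoxy group, an amine or a carboxylic acid, would stay in this range or move clearly away from it. They also leave open how a plain phenyl ring without any substituent would compare, and whether the hydroxyl group on the shared core matters for the read-out.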